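Compound 2 to compound 4: a larger hydroxylated group

A few compounds are considered here, and "the series" means these few. Any claim that something is new, unique, unknown or untested is made for them only; others in the source may bear on it.

In a functional assay on SH-SY5Y cells (Homo sapiens) for cytotoxicity, read by MTT assay, with a stated time of 72 h (on this read-out lower numbers stand for stronger inhibition and higher numbers for weaker inhibition), compound 1 `CC1(C)OCC(Cn2cc(Cn3c4c(c5ccccc53)C(=O)c3c[n+]([O-])c5ccccc5c3C4=O)nn2)O1` gives 230 nM and compound 3 `CN1CCN(CCCCn2c3c(c4ccccc42)C(=O)c2c[n+]([O-])c4ccccc4c2C3=O)CC1` gives 100 nM. Compound 2 `O=C1c2c[n+]([O-])c3ccccc3c2C(=O)c2c1c1ccccc1n2Cc1cn(CC(O)CO)nn1` reads > 1000 nM, which is a limit and not a number. It stands at the limit of > 1000 nM in this assay, at which 1 of the 3 values shown sits.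

Compound 4 `O=C1c2c[n+]([O-])c3ccccc3c2C(=O)c2c1c1ccccc1n2Cc1cn([C@@H]2O[C@H](CO)[C@@H](O)[C@H](O)[C@H]2O)nn1` carries 3,4,5-trihydroxy-6-(hydroxymethyl)oxan-2-yl in place of 2,3-dihydroxypropyl on an aromatic nitrogen. For the measured compounds named here, two measured steps bear on this only indirectly: an at least 4.3-fold higher number from compound 1 to compound 2 (0.63 log units; beyond the scatter) and an at least 10-fold lower number from compound 2 to compound 3 (1.00 log units; beyond the scatter). Both leave compound 2, with its free hydroxyl groups, at the weak end, and compound 4 also carries free hydroxyl groups. No step beyond the scatter is therefore expected, and another limit reading is likely. The expected change is a step that the limit leaves unreadable from compound 2 to compound 4. For compound 4 the estimated value is 2500 nM, with an expected range of 1000 nM to 8000 nM.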

Compound 4, half-maximal inhibitory concentration: 880 nM
Beside the measured number, compound 4's estimate is 2.8-fold (0.45 log units) above it, outside the stated range (below it).
By their numbers in this assay, from the lowest: compound 3; then compound 1; then compound 4. At a limit, above all of these: compound 2.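

In this assay, the 3,4,5-trihydroxy-6-(hydroxymethyl)oxan-2-yl group on this aromatic nitrogen gives compound 4 a readable number, whereas compound 2 stands at a limit. That limit leaves only an at least 1.1-fold lower number from compound 2 to compound 4 (0.05 log units; that floor lies within the scatter), so no gain over 2,3-dihydroxypropyl can be claimed. Measured against (2,2-dimethyl-1,3-dioxolan-4-yl)methyl, the same group gives a 3.8-fold higher number from compound 1 to compound 4 (0.58 log units; beyond the scatter), which places a free-hydroxyl group on the weaker side by a readable step.

The compounds shown leave open how a carboxylic acid or a primary amine would read on this aromatic nitrogen. They also leave open whether the six-membered non-aromatic ring or the hydroxyl groups set the reading of compound 4.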